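This account rests on a few compounds, and the source may have more. Where it says the series, first, only, none or still open, it means among the compounds named here.

Measured so far in a functional assay on SMMC-7721 cells (Homo sapiens) for cytotoxicity, read by MTT assay, with a stated time of 4 days; on this read-out higher numbers stand for weaker inhibition and lower numbers for stronger inhibition:
compound 1 `C=C1C(=O)[C@]23C[C@@]1(O)CC[C@H]2c1ccc(OS(=O)(=O)c2ccc(C)cc2)c(C)c1[C@@H]3Cn1cc(-c2ccc(Cl)cc2)nn1`, 6180 nM
compound 2 `C=C1C(=O)[C@]23C[C@@]1(O)CC[C@H]2c1ccc(O)c(C)c1[C@@H]3Cn1cc(-c2ccc(Cl)cc2)nn1`, 670 nM

Compound 1 gives the highest of the two numbers; its nearest neighbour is compound 2, reached by a 9.2-fold lower number from compound 1 to compound 2 (0.96 log units; beyond the scatter), the change being hydrogen in place of (4-methylphenyl)sulfonyl on an oxygen on an aromatic ring.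

Compound 3 `C=C1C(=O)[C@]23C[C@@]1(O)CC[C@H]2c1ccc(OS(=O)(=O)c2ccc(C)cc2)c(C)c1[C@@H]3Cn1cc(-c2ccc(C)cc2)nn1` differs from compound 1 only by methyl in place of chloro on an aromatic carbon, on an aromatic carbon of a six-membered aromatic ring of carbon only, para to a large group. The (4-methylphenyl)sulfonyl group of compound 1 is retained. Within the data shown here, no measured step touches this part of the structure: the single step in hand, from compound 1 to compound 2, concerns the sulfonyl ester and gives no guide to an exchange on the aryl-triazole. The step from compound 1 to compound 3 in this assay is therefore expected to be a 1.0-fold lower number from compound 1 to compound 3 (0.01 log units; within the scatter), not beyond the scatter in either direction. Compound 3 is estimated at 6000 nM, in the range 2000 nM to 18000 nM.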

Compound 3, half-maximal inhibitory concentration: 4410 nM
The estimate for compound 3 lay 1.4-fold (0.13 log units) above the measured number; low and high end bracket the measured number.
By their numbers in this assay, from the lowest: compound 2; then compounds 3 and 1 (each within the scatter of the next).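

In this assay, replacing chloro with methyl, which turns the 4-chlorophenyl group into 4-methylphenyl while the (4-methylphenyl)sulfonyl group stays in place, gives a 1.4-fold lower number from compound 1 to compound 3 (0.15 log units; within the scatter). This first reading at this position shows that this exchange does not move the number beyond the scatter, whereas the change at the oxygen gave a 9.2-fold lower number from compound 1 to compound 2 (0.96 log units; beyond the scatter). Nothing in hand accounts for this result.

The compounds shown leave open whether methyl in place of chloro would read the same on compound 2, which carries hydrogen rather than the sulfonyl group on that oxygen. Also open, on these data alone, is how an amine, a carboxylic acid or a longer alkyl chain on the same aromatic carbon would read in this assay.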